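Adding a Hydroxy Group to the Weakest Analogue

A few compounds are considered here, and "the series" means these few. Any claim that something is new, unique, unknown or untested is made for them only; others in the source may bear on it.

Of the compounds shown here, three have been measured in an assay on cells for inhibition of Indoleamine 2,3-dioxygenase 1 (Homo sapiens), read by HPLC, with a stated time of 20 min; a higher number here means a weaker inhibitor, a lower number a stronger inhibitor. Compound 1 `Nc1ccc(Cl)cc1-c1cnc[nH]1` gives 12100 nM, compound 2 `Cn1cncc1-c1cc(Cl)ccc1O` gives 17000 nM, and compound 3 `Clc1cccc(-n2ccnc2)c1` gives 41000 nM, the highest of the three numbers; compound 2 is its nearest neighbour with a lower number beyond the scatter, and compound 1 lies furthest from it, also beyond the scatter. Compound 4 `Oc1ccc(Cl)cc1-n1ccnc1` has not yet been tested. It differs from compound 3 by hydroxy in place of hydrogen on an aromatic carbon, that is, a hydroxy in place of hydrogen on an aromatic carbon. A modest move toward a lower number is expected, a 2.3-fold lower number from compound 3 to compound 4 (0.36 log units; beyond the scatter), because compound 2 also carries a hydroxy and gives 17000 nM. Compound 4 is therefore estimated at 18000 nM, within a range of 7000 nM to 45000 nM.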

Compound 4, half-maximal inhibitory concentration: 2100 nM
The estimate for compound 4 lay 8.6-fold (0.93 log units) above the measured number; measured number outside the range, below it.
By their numbers in this assay, from the lowest: compound 4; then compounds 1 and 2 (each within the scatter of the next); then compound 3.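

Hydroxy in place of hydrogen on an aromatic carbon, ortho to a group of 5 heavy atoms and para to a chloro group, gives a 20-fold lower number from compound 3 to compound 4 (1.29 log units; beyond the scatter) in this assay, a large step. For the compounds shown here, the earlier compounds offered no pair differing in one place, so this is the first direct reading of a single change, and it shows that this one position can by itself shift the number by a large amount.

On these data alone, whether a methoxy group or a fluoro group in the same place would give a similar step remains open. Nothing shown accounts for the size of this step.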